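Swapping one ring for another and watching rat exposure

The compounds below may be only part of what the source reports. "The series", "measured", "known", "first", "only" and "open" are said of these compounds alone.

In an ADME assay on the whole organism (plasma, strain Sprague-Dawley) for pharmacokinetics, with Rattus norvegicus as the target, read by LC-MS, at a dose of 25 mg/kg by the oral route (on this read-out lower numbers stand for lower exposure and higher numbers for higher exposure at the dose given), compound 3 `C=CC(=O)N1CC[C@H](N2C(=O)N(c3ccccc3)Cc3cnc(Nc4ccc(C5CCN(C)CC5)cc4)nc32)C1` gives 1310 ng.h/mL. Two companions carry a 4-methylpiperazin-1-yl group rather than its 1-methylpiperidin-4-yl: compound 1 `C=CC(=O)N1CC[C@H](N2C(=O)N(c3ccccc3)Cc3cnc(Nc4cccc(N5CCN(C)CC5)c4)nc32)C1` gives 760 ng.h/mL and compound 2 `C=CC(=O)N1CC[C@H](N2C(=O)N(c3ccccc3)Cc3cnc(Nc4ccc(N5CCN(C)CC5)c(OC)c4)nc32)C1` gives 948 ng.h/mL. Both of these numbers sit within the usual scatter of the value for compound 3, so the three compounds cannot be told apart on this read-out; no ranking among them is supported.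

Compound 4 `C=CC(=O)N1CC[C@H](N2C(=O)N(c3ccccc3)Cc3cnc(Nc4ccc(N5CCN(C)CC5)cc4)nc32)C1` is the untested partner of compound 3. The change is 4-methylpiperazin-1-yl in place of 1-methylpiperidin-4-yl on an aromatic carbon, placed on an aromatic carbon of a six-membered aromatic ring of carbon only, para to a large group. Nothing measured connects these two compounds directly, yet compounds 1 and 2, which already hold the entering group, give numbers close to that of compound 3.

The step is therefore expected to be small, a 1.4-fold lower number from compound 3 to compound 4 (0.14 log units; within the scatter), not beyond the scatter. Compound 4 is estimated at 950 ng.h/mL, within 450 ng.h/mL to 1900 ng.h/mL.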

Compound 4, area under the concentration-time curve: 2310 ng.h/mL
Estimate against measurement, compound 4: 2.4-fold (0.39 log units) below, and the stated range ends below it.
By their numbers in this assay, from the lowest: compounds 1, 2, 3 and 4 (each within the scatter of the next, the first and the last beyond it).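

Exchanging 1-methylpiperidin-4-yl for 4-methylpiperazin-1-yl on this aromatic carbon gives a 1.8-fold higher number from compound 3 to compound 4 (0.25 log units; within the scatter), so in this assay the two rings cannot be told apart. The methoxy group is different: hydrogen in place of methoxy on an aromatic carbon gives a 2.4-fold higher number from compound 2 to compound 4 (0.39 log units; beyond the scatter), a modest step and the only single-place change here that clears the scatter, which shows that this substituent on the aromatic ring can shift exposure while the ring exchange cannot be shown to. No evidence here explains why the methoxy change shifts exposure.

The compounds shown leave open whether a morpholine ring in place of 4-methylpiperazin-1-yl would give a similar number. They also leave open whether fluorine or ethoxy in place of methoxy would behave like hydrogen or like methoxy.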